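Replacing the Benzothiazole Group of Compound 1

The compounds below may be only part of what the source reports. "The series", "measured", "known", "first", "only" and "open" are said of these compounds alone.

Measured so far:
Compound 1 `C=C(CC)C(=O)c1ccc(OCC(=O)Nc2nc3ccccc3s2)c(Cl)c1Cl` reads (1500 nM)
Compound 2 `C=C(CC)C(=O)c1ccc(OCC(=O)Nc2ccc(C(=O)NC(CCC(=O)OCC)C(=O)OCC)cc2)c(Cl)c1Cl` reads (2100 nM)

Both numbers come from a functional assay on CLL cells (Homo sapiens) for cytotoxicity, read by MTT assay, with a stated time of 48 h; on this read-out lower numbers stand for an effect already at smaller amounts and higher numbers for an effect only at larger amounts of compound. The gap between compound 1 (1500 nM) and compound 2 (2100 nM) lies within the usual scatter of repeated measurements, so the two cannot be ranked. For the measured compounds named here, compound 1 therefore offers a sound starting point, but not a clear lead over its only measured neighbour.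

Compound 3 `C=C(CC)C(=O)c1ccc(OCC(=O)Nc2ccc(O)c(Cl)c2)c(Cl)c1Cl` keeps the core of compound 1 and carries 3-chloro-4-hydroxyphenyl in place of 1,3-benzothiazol-2-yl on an amide-type nitrogen. Going by the values given here, no two measured compounds differ in just one place, so the data hold no direct guide to the size of such a swap. Among the compounds with values here, the only hint is that compound 2 (2100 nM) falls within the scatter of compound 1. A shift beyond the scatter is therefore not expected in either direction, and the estimated 1.3-fold higher number from compound 1 to compound 3 (0.12 log units; within the scatter) is small. The estimate for compound 3 is 2000 nM (expected range 700 nM to 6000 nM).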

Compound 3, half-maximal effective concentration: 5500 nM
Beside the measured number, compound 3's estimate is 2.8-fold (0.44 log units) below it; measured number inside the range.
By their numbers in this assay, from the lowest: compounds 1 and 2 (each within the scatter of the next); then compound 3.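

In this assay, for the compounds shown here, the exchange of 1,3-benzothiazol-2-yl for 3-chloro-4-hydroxyphenyl on the amide-type nitrogen gives a 3.7-fold higher number from compound 1 to compound 3 (0.56 log units; beyond the scatter) and is the only step so far that can be read beyond the usual scatter, so what sits at this position can change the amount of compound needed for an effect. The step is modest, and it replaces several features at once: the two-ring group gives way to a single six-membered carbon ring that carries a chlorine and a hydroxyl group, so the data cannot assign the step to any one of these features. No measured property accompanies this step, and the result therefore comes without an explanation.

Still open, on these data alone, is which part of the entering group goes with the higher number, since a phenyl ring carrying only the chlorine or only the hydroxyl group would be needed to separate the two. Also open, as far as these compounds go, is how an amine or a carboxylic acid on that phenyl ring, or a methoxy group in place of the hydroxyl group, would read in this test of the same position.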